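The compounds below may be only part of what the source reports. "The series", "measured", "known", "first", "only" and "open" are said of these compounds alone.

Of the compounds shown here, three sharing one core have been tested in a functional assay (strain Wistar) with Rattus norvegicus as the target, read by LDH release; on this read-out higher numbers stand for an effect only at larger amounts of compound and lower numbers for an effect already at smaller amounts. Compound 1 `CN/C(C)=N/C1=Nc2ccccc2CS1` gives 0.01 uM in this assay, compound 3 `CCN(CC)/C(C)=N/C1=Nc2ccccc2CS1` gives 0.1 uM, and compound 2 `CCCN(CCC)/C(C)=N/C1=Nc2ccccc2SC1`, whose core differs at one point, gives 10 uM. Compound 3 therefore stands second highest of the three numbers: the step of a 10-fold higher number from compound 1 to compound 3 (1.00 log units; beyond the scatter) separates it from compound 1, and compound 2 lies further off. Compound 4 `C/C(=N\C1=Nc2ccccc2CS1)N(C)C` is the next step, (dimethylamino in place of diethylamino on a carbon with a double bond to nitrogen). Only a 10-fold higher number from compound 1 to compound 3 (1.00 log units; beyond the scatter) bears on this, since dimethylamino lies between the methylamino of compound 1 and the diethylamino of compound 3; a modest step down in this assay is therefore expected, a 3.3-fold lower number from compound 3 to compound 4 (0.52 log units; beyond the scatter). Compound 4 is estimated at 0.03 uM, with a range from 0.01 uM to 0.1 uM.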

Compound 4, minimum effective concentration: 0.1 uM
The estimate for compound 4 lay 3.3-fold (0.52 log units) below the measured number; measured number inside the range.
By their numbers in this assay, from the lowest: compound 1; then compounds 3 and 4 (each within the scatter of the next); then compound 2.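

In this assay, dimethylamino in place of diethylamino on this carbon gives no change at the digits printed from compound 3 to compound 4 (within the scatter), so going from ethyl to methyl chains on a fully substituted nitrogen makes no difference here. Methyl in place of hydrogen on the amine nitrogen, by contrast, gives a 10-fold higher number from compound 1 to compound 4 (1.00 log units; beyond the scatter), which places the larger change at that nitrogen hydrogen rather than in the chain length. Nothing measured here explains either result. Still open, on these data alone, is how an unsubstituted amino group, or a ring amine such as pyrrolidine, would read at this place on the shared core.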